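The source may hold more compounds than are shown below. What is called first, only, known or untested is meant among the compounds shown, and "the series" means these compounds.

Of the compounds shown here, two of a shared core have been measured in a physicochemical assay for solubility, measured as kinetic solubility, at pH 2; on this read-out higher numbers stand for higher solubility and lower numbers for lower solubility. Compound 1, `CC(C)C(c1ccc(-c2ccc3cccc(F)c3c2)[nH]c1=O)N1CCN/C1=N\C#N`, gives 32500 nM in this assay. Compound 2, `CC(C)C(c1noc(=O)[nH]1)c1ccc(-c2ccc3cccc(F)c3c2)[nH]c1=O`, gives 23200 nM in this assay. Within the data shown here, compound 2 thus has the lower of the two numbers, but the only step among them, a 1.4-fold lower number from compound 1 to compound 2 (0.15 log units; within the scatter), is too small to be read as a real difference.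

Compound 3, `Cc1c[nH]c(C(c2ccc(-c3ccc4cccc(F)c4c3)[nH]c2=O)C(C)C)n1`, has not been measured. Compared with compound 2 the change is a group of 6 heavy atoms (4 carbon, 2 nitrogen; one five-membered aromatic ring with 2 hetero atoms) in place of a group of 6 heavy atoms (2 carbon, 2 nitrogen, 2 oxygen; one five-membered aromatic ring with 3 hetero atoms), on a saturated chain carbon bound to an aromatic carbon and a saturated chain carbon. Among the measured compounds shown here, the only measured step at the same place is a 1.4-fold lower number from compound 1 to compound 2 (0.15 log units; within the scatter), and it stays within the scatter even though it replaced a ring of a different kind and size. That step therefore gives no reason to expect the new change to move the number far in either direction. With nothing else to go on, compound 3 is expected to come out close to compound 2, with the expected step being a 1.7-fold higher number from compound 2 to compound 3 (0.24 log units; within the scatter). The estimate for compound 3 in this assay is 40000 nM, with a range from 15000 nM to 110000 nM.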

Compound 3, solubility: 6300 nM
The estimate for compound 3 lay 6.3-fold (0.80 log units) above the measured number; measured number outside the range, below it.
By their numbers in this assay, from the lowest: compound 3; then compounds 2 and 1 (each within the scatter of the next).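

At this saturated chain carbon, the choice of group can matter in this assay: putting 4-methyl-1H-imidazol-2-yl in place of the ring with 3 hetero atoms gives a 3.7-fold lower number from compound 2 to compound 3 (0.57 log units; beyond the scatter), and the comparison with the non-aromatic ring gives a 5.2-fold lower number from compound 1 to compound 3 (0.71 log units; beyond the scatter). Both steps lie beyond the scatter, so the small step between the first two compounds did not mean that this position tolerates any ring, and compound 3 has the lowest number of the three. The two aromatic rings have the same count of 6 heavy atoms but differ in their atoms, and the entering ring has 1 hydrogen-bond acceptor where the leaving ring has 3, yet no measurement here shows which of these differences accounts for the drop.

The compounds shown leave open whether the lower number goes with the imidazole ring itself or with its methyl group, a question that an imidazol-2-yl group without the methyl at the same carbon would address. They also leave open how a group without a ring, such as an amine or a carboxylic acid, would compare at this position.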